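Shifting the amide aryl group from methoxyphenyl to fluorophenyl

The source may hold more compounds than are shown below. What is called first, only, known or untested is meant among the compounds shown, and "the series" means these compounds.

Three amides sharing one core have been measured in a functional assay on MCF7 cells (Homo sapiens) for antiproliferative activity, read by CCK-8 assay, with a stated time of 72 h; on this read-out higher numbers stand for weaker inhibition and lower numbers for stronger inhibition. Compound 1 `O=C(Nc1cccc(-c2oc3cc(-c4ccc(F)cc4)ccc3c(=O)c2O)c1)c1ccc(F)cc1` gives 8590 nM, compound 2 `COc1ccccc1C(=O)Nc1cccc(-c2oc3cc(-c4ccc(F)cc4)ccc3c(=O)c2O)c1` gives 2100 nM, and compound 3 `O=C(Nc1cccc(-c2oc3cc(-c4ccc(F)cc4)ccc3c(=O)c2O)c1)c1ccc(C(F)(F)F)cc1` gives 32600 nM. Compound 2 thus holds the lowest number of the three, with a 4.1-fold lower number from compound 1 to compound 2 (0.61 log units; beyond the scatter) and a 16-fold higher number from compound 2 to compound 3 (1.19 log units; beyond the scatter). Compound 4 `O=C(Nc1cccc(-c2oc3cc(-c4ccc(F)cc4)ccc3c(=O)c2O)c1)c1cccc(F)c1` differs from compound 2 by 3-fluorophenyl in place of 2-methoxyphenyl on a carbonyl carbon. The nearest measured step, from compound 2 to compound 1, swaps the same methoxyphenyl for a fluorophenyl, so a rise of similar size is expected for compound 4, giving a 3.3-fold higher number from compound 2 to compound 4 (0.52 log units; beyond the scatter). Compound 4 is therefore estimated at 7000 nM in this assay, within 2500 nM to 20000 nM.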

Compound 4, half-maximal inhibitory concentration: 5770 nM
Compound 4: the middle estimate sits 1.2-fold (0.08 log units) above what was measured, and the stated range covers the measured number.
By their numbers in this assay, from the lowest: compound 2; then compounds 4 and 1 (each within the scatter of the next); then compound 3.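

In this assay, 3-fluorophenyl and 4-fluorophenyl on the carbonyl carbon cannot be told apart, with a 1.5-fold lower number from compound 1 to compound 4 (0.17 log units; within the scatter), so moving the fluorine does not register here. The 3-fluorophenyl amide still stays clear of the other two groups, with a 2.7-fold higher number from compound 2 to compound 4 (0.44 log units; beyond the scatter) and a 5.6-fold lower number from compound 3 to compound 4 (0.75 log units; beyond the scatter). Nothing available here accounts for these differences.

The compounds shown leave open whether the lower number of compound 2 depends on where the methoxy group sits, as no 3-methoxyphenyl or 4-methoxyphenyl amide appears. They also leave open how 2-fluorophenyl or an aminophenyl group would read at this position.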